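Triazole-linked sulfonate series: third para-substituted analogue pending

This account rests on a few compounds, and the source may have more. Where it says the series, first, only, none or still open, it means among the compounds named here.

Measured so far in a functional assay on MCF7 cells (Homo sapiens) for cytotoxicity, read by MTT assay, with a stated time of 4 days; a higher number here means a weaker inhibitor, a lower number a stronger inhibitor:
- Compound 1 `C=C1C[C@]23C[C@@]1(O)CC[C@H]2c1ccc(OS(=O)(=O)c2ccc(C)cc2)c(C)c1[C@@H]3Cn1cc(-c2ccc(Cl)cc2)nn1`: the value > 20000 nM is a limit of this assay, not a number.
- Compound 2 `C=C1C[C@]23C[C@@]1(O)CC[C@H]2c1ccc(OS(=O)(=O)c2ccc(C)cc2)c(C)c1[C@@H]3Cn1cc(-c2ccc(C)cc2)nn1`: the value > 20000 nM is likewise a limit of this assay.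

Going by the values given here, compound 2 therefore stands at the limit of this assay, with no numerical potency to place it; the only other value shown, that of compound 1, is a limit as well. Among the compounds with values here, the one measured step, methyl in place of chloro on an aromatic carbon, reads a step that the two limits leave unreadable from compound 1 to compound 2, so it carries no information on size or direction. The whole picture is the limit of > 20000 nM in this assay, at which 2 of the 2 values shown sit.

Compound 3 `C=C1C[C@]23C[C@@]1(O)CC[C@H]2c1ccc(OS(=O)(=O)c2ccc(C)cc2)c(C)c1[C@@H]3Cn1cc(-c2ccc(C(F)(F)F)cc2)nn1` differs from compound 2 by trifluoromethyl in place of methyl on an aromatic carbon. Within the data shown here, no measured step bears on this change in a readable way; the closest comparison, the step from compound 1 to compound 2, is itself unreadable. Nothing in the series suggests a move off the limit, so no step beyond the scatter is expected in this assay, and the estimated step is a step that the limit leaves unreadable from compound 2 to compound 3. Compound 3 is expected to remain at or near the limit of this assay, estimated at 30000 nM with a range of 10000 nM to 100000 nM, most likely reported again only as a limit.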

Compound 3, half-maximal inhibitory concentration: > 20000 nM
Compound 3: only a limit was reported (the forecaster's own chance of this, stated with the estimate: 85%); the middle value lies beyond the limit too.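

No step can be read among compound 1, compound 2 and compound 3 in this assay, because all three values are limits of the assay and not numbers: the limit of > 20000 nM in this assay, at which 3 of the 3 values shown sit.

The compounds shown leave open whether any change at this aromatic carbon, or elsewhere on the shared core, would give a measurable value.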